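Swapping the arm on the ring nitrogen of compound 2

This account rests on a few compounds, and the source may have more. Where it says the series, first, only, none or still open, it means among the compounds named here.

Of the compounds shown here, two have been tested in an in vitro functional assay on RBL cells for antagonist activity at C-C chemokine receptor type 8 (Homo sapiens), read by FLIPR and calcium flux; a lower number here means a stronger inhibitor, a higher number a weaker inhibitor. Compound 1, `COc1ccc2nccc(C3CN(C4CCN(Cc5cc6ccccc6[nH]5)CC4)C(=O)O3)c2n1`, gives 31.6 nM. Compound 2, `COc1ccc2nccc(C3CN(C4CCN(Cc5cc6ccccc6o5)CC4)C(=O)O3)c2c1`, gives 1260 nM. Of these two numbers, compound 2 has the higher one, so it is the weaker inhibitor of the pair, and the gap to compound 1 is far wider than the scatter of repeated measurements. The two compounds differ in more than one place, so nothing can be said about which part of the structure carries that gap.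

Compound 3, `COc1ccc2nccc(C3CN(C4CCN(S(=O)(=O)c5ccc(Cl)c(Cl)c5)CC4)C(=O)O3)c2c1`, has not yet been measured in this assay. It is derived from compound 2 by a single change: (3,4-dichlorophenyl)sulfonyl in place of (1-benzofuran-2-yl)methyl on an amine nitrogen in a ring. Going by the values given here, no measured pair shows what such an exchange does to the read-out, so the expectation must rest on the single starting point.

With no measured neighbour to lean on, the step of a 2.4-fold higher number from compound 2 to compound 3 (0.38 log units; beyond the scatter) is estimated as a move towards a higher number, larger than the scatter but not assured. Compound 3 is therefore expected to give about 3000 nM, somewhere between 600 nM and 15000 nM.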

Compound 3, half-maximal inhibitory concentration: < 50200 nM
Compound 3 ended at the assay's limit; the forecaster's own chance of this, stated with the estimate: 25%; the middle value is on the limit's open side.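

In this assay compound 3 gives < 50200 nM, which is a limit of the assay and not a number, so the step from compound 2 to compound 3 cannot be read. The compounds shown leave open how far, and in which direction, (3,4-dichlorophenyl)sulfonyl in place of (1-benzofuran-2-yl)methyl on an amine nitrogen in a ring moves the read-out.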